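Removing the Butoxy Group from Compound 2

The source may hold more compounds than are shown below. What is called first, only, known or untested is meant among the compounds shown, and "the series" means these compounds.

In a functional assay on MT4 cells (Homo sapiens) for cytotoxicity (on this read-out lower numbers stand for stronger inhibition and higher numbers for weaker inhibition), compound 1 `CCCOc1cc(C)cc(S(=O)(=O)c2cccc(N)c2C#N)c1` gives 11000 nM. Compound 2 `CCCCOc1cc(C)cc(S(=O)(=O)c2cccc(N)c2C#N)c1` gives > 2000 nM, which is a limit of the assay and not a number. Compound 3 `Cc1cccc(S(=O)(=O)c2cccc(N)c2C#N)c1` differs from compound 2 by a single change, hydrogen in place of butoxy on an aromatic carbon. For the measured compounds named here, one measured step bears on this change, a step that the limit leaves unreadable from compound 1 to compound 2. It has no readable size, and it alters the length of the chain without removing it, so it gives no firm guide. Going by the values given here, the only true number nearby is the one for compound 1, at 11000 nM, so the expectation stays close to that value in this assay. The expected change is a step that the limit leaves unreadable from compound 2 to compound 3, leaning slightly towards weaker inhibition, though this is a loose estimate. For compound 3 the estimated value is 15000 nM, with a likely range of 5000 nM to 50000 nM.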

Compound 3, half-maximal inhibitory concentration: 179000 nM
For compound 3 the middle estimate is 12-fold (1.08 log units) below the measured one; measured number outside the range, above it.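

In this assay, replacing the propoxy group with hydrogen gives a 16-fold higher number from compound 1 to compound 3 (1.21 log units; beyond the scatter), which is a large move towards weaker inhibition and lies beyond the usual scatter. For the compounds shown here, this is the first readable step at this aromatic carbon, meta to a large group and meta to a methyl group, and it shows that the read-out depends strongly on what sits there. Compound 2 has only a limit of the assay and not a number, and its steps to compound 1 and compound 3 cannot be read because of it: the limit of > 2000 nM in this assay, at which 1 of the 3 values shown sits.

The compounds shown leave open how butoxy compares with propoxy or with hydrogen in size of effect. They also do not separate the part played by the oxygen from that of the carbon chain, which a hydroxyl group, a methoxy group or a plain propyl chain on this carbon could address.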